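A few compounds are considered here, and "the series" means these few. Any claim that something is new, unique, unknown or untested is made for them only; others in the source may bear on it.

Going by the values given here, compound 3 `CCCNC(=S)Nc1cccc(OCCCCCc2ccccc2)c1` is the only member of this small group with a numbered read-out in an ADME assay on Ava5 cells (Homo sapiens) for cytotoxicity (on this read-out lower numbers stand for higher toxicity in this test and higher numbers for lower toxicity in this test), where compound 3 gives 32000 nM. Compound 1 `NC(=S)Nc1cccc(NCCCCCc2ccccc2)c1` reaches only a limit of this assay, > 50000 nM. Compound 2 `CCNC(=S)Nc1cccc(OCCCCCc2ccccc2)c1` likewise stops at a limit, > 50000 nM. Among the compounds with values here, the single measured change is the step of an at least 1.5-fold lower number from compound 2 to compound 3 (0.19 log units; that floor lies within the scatter), which must be read against (the limit of > 50000 nM in this assay, at which 2 of the 3 values shown sit). Compound 4 `S=C(NCc1ccccc1)Nc1cccc(OCCCCCc2ccccc2)c1` differs from compound 3 by phenyl in place of ethyl on a saturated chain carbon bound to an amide-type nitrogen. This change adds more than the earlier step did, yet that step stayed within the scatter, so for compound 4 a step of a 1.3-fold lower number from compound 3 to compound 4 (0.11 log units; within the scatter) is expected, with a fair chance that this assay again reports only a limit. Compound 4 is estimated at 25000 nM, between 8000 nM and 80000 nM.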

Compound 4, half-maximal cytotoxic concentration: 32000 nM
Beside the measured number, compound 4's estimate is 1.3-fold (0.11 log units) below it; measured number inside the range.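

In this assay, phenyl in place of ethyl on a saturated chain carbon bound to an amide-type nitrogen gives no change at the digits printed from compound 3 to compound 4 (within the scatter). This place therefore takes a six-membered aromatic ring and still yields a numbered read-out, not a limit. The comparison with the ethylamino compound gives only an at least 1.5-fold lower number from compound 2 to compound 4 (0.19 log units; that floor lies within the scatter), and that step remains a floor: the limit of > 50000 nM in this assay, at which 2 of the 4 values shown sit.

Going by these compounds, whether an amine or a carboxylic acid on the new phenyl ring would move this read-out beyond the scatter stays open. So does the effect of a longer chain between that ring and the amide-type nitrogen.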